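Lengthening the chain on a tert-butyl nitrone triazole

This account rests on a few compounds, and the source may have more. Where it says the series, first, only, none or still open, it means among the compounds named here.

For the measured compounds named here, compound 3 `CCCCCCCCn1cc(/C=[N+](\[O-])C(C)(C)C)nn1` is the only member of this set with a numeric result: in a functional assay on A549 cells (Homo sapiens) for inhibition, read by MTT assay, with a stated time of 24 h (on this read-out higher numbers stand for weaker inhibition and lower numbers for stronger inhibition), compound 3 gives 31300 nM. Compound 1 `CCCCCCCCCCn1cc(/C=[N+](\[O-])c2ccccc2)nn1` reaches a limit of the assay, as in this assay compound 1 gives > 100000 nM. Compound 2 `CCCCCCCCCCn1cc(/C=[N+](\[O-])Cc2ccccc2)nn1` likewise stops at a limit, since compound 2 gives > 100000 nM. The step from compound 1 to compound 2 is therefore unreadable, a step that the two limits leave unreadable from compound 1 to compound 2, and the limit of > 100000 nM in this assay, at which 2 of the 3 values shown sit, marks where those two values sit. Compound 4 `CCCCCCCCCCn1cc(/C=[N+](\[O-])C(C)(C)C)nn1` differs from compound 3 by ethyl in place of hydrogen on a saturated chain carbon, eight bonds along the chain from an aromatic nitrogen. Going by the values given here, no measured step bears on this change, so no shift beyond the scatter is expected, and the step from compound 3 to compound 4 is estimated as a 1.1-fold higher number from compound 3 to compound 4 (0.05 log units; within the scatter). Compound 4 is expected to give 35000 nM, within 12000 nM to 100000 nM.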

Compound 4, half-maximal inhibitory concentration: 24800 nM
For compound 4 the middle estimate is 1.4-fold (0.15 log units) above the measured one; measured number inside the range.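

In this assay the chain change gives a 1.3-fold lower number from compound 3 to compound 4 (0.10 log units; within the scatter), so ethyl in place of hydrogen at this position shows no shift beyond the scatter. With the decyl-length chain shared, the group on the double-bonded nitrogen now separates the compounds: tert-butyl in place of benzyl gives an at least 4.0-fold lower number from compound 2 to compound 4 (0.60 log units; beyond the scatter), and tert-butyl in place of phenyl gives an at least 4.0-fold lower number from compound 1 to compound 4 (0.60 log units; beyond the scatter). Both steps start from a limit of the assay rather than a number: the limit of > 100000 nM in this assay, at which 2 of the 4 values shown sit.

The compounds shown leave open whether a longer chain would stay within the scatter of compound 4. They also leave open how an amine or a carboxylic acid at the chain end would read.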